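The compounds below may be only part of what the source reports. "The series", "measured", "known", "first", "only" and "open" are said of these compounds alone.

Of the compounds shown here, three from this series have been tested in a functional assay on MCF7 cells (Homo sapiens) for cytotoxicity, read by MTT assay, with a stated time of 4 days (on this read-out higher numbers stand for weaker inhibition and lower numbers for stronger inhibition), and every one of them reached only the limit of the assay. Compound 1 `Cc1ccc(S(=O)(=O)Oc2ccc3c(c2C)[C@H](Cn2cc(-c4ccc(Cl)cc4)nn2)[C@@]24CC(=O)[C@@](C)(CC[C@@H]32)C4)cc1` gives > 20000 nM in this assay, a limit rather than a number. Compound 3 `COc1ccc(-c2cn(C[C@H]3c4c(ccc(OS(=O)(=O)c5ccc(C)cc5)c4C)[C@@H]4CC[C@@]5(C)C[C@]43CC5=O)nn2)cc1` gives > 20000 nM in this assay, again a limit. Compound 2 `C=C1C[C@]23C[C@@]1(O)CC[C@@H]2c1cccc(C)c1[C@@H]3Cn1cc(-c2ccc(OC)cc2)nn1` gives > 20000 nM in this assay, also a limit.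

Compounds 3 and 1 differ in one place: chloro in place of methoxy on an aromatic carbon. Because both values are limits, the step that the two limits leave unreadable from compound 3 to compound 1 cannot be read, and the same holds for any comparison among these three, since (the limit of > 20000 nM in this assay, at which 3 of the 3 values shown sit).

Compound 4 `C=C1C[C@]23C[C@@]1(O)CC[C@@H]2c1cccc(C)c1[C@@H]3Cn1cc(-c2ccc(Cl)cc2)nn1` is not yet measured. It is related to compound 2 by the same change that separates compound 3 from compound 1: chloro in place of methoxy on an aromatic carbon. The cores of compound 2 and compound 3 differ in more than one place, and that difference is not broken down here.

Within the data shown here, the only evidence on this change is the pair of limits for compound 3 and compound 1, which leaves its size unreadable. The step from compound 2 to compound 4 is therefore expected to be a step that the limit leaves unreadable from compound 2 to compound 4, resting on nothing more than the observation that chloro in place of methoxy on an aromatic carbon did not bring compound 1 below the limit of this assay. Compound 4 is expected to give about 30000 nM in this assay, within 10000 nM to 100000 nM, most likely reported as a limit.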

Compound 4, half-maximal inhibitory concentration: > 20000 nM
Compound 4 gave a limit, no number (the forecaster's own chance of this, stated with the estimate: 85%); the middle value does not contradict the limit.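

Compound 4 also stops at a limit rather than a number, so the step from compound 2 to compound 4 cannot be read, and no new comparison follows: the limit of > 20000 nM in this assay, at which 4 of the 4 values shown sit.

Still open is whether, in this assay, any of these compounds has a measurable potency, and whether chloro in place of methoxy changes it at all.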